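The compounds below may be only part of what the source reports. "The series", "measured", "known", "first", "only" and "open" are said of these compounds alone.

Among the measured compounds shown here, compound 2 `COc1ccc(C(=O)Nc2c(F)cccc2F)cc1OC1CCCC1` holds the lowest of the two numbers so far in an assay on isolated protein for inhibition of phosphodiesterase 4A (Sus scrofa) (on this read-out higher numbers stand for weaker inhibition and lower numbers for stronger inhibition), where compound 2 gives 70 nM; compound 1 `COc1ccc(C(=O)Nc2ccccc2Br)cc1OC1CCCC1` gives 130 nM, and the step of a 1.9-fold lower number from compound 1 to compound 2 (0.27 log units; within the scatter) lies within the scatter. Compound 3 `O=C(Nc1c(F)cccc1F)c1cccc(OC2CCCC2)c1` differs from compound 2 in one place: hydrogen in place of methoxy on an aromatic carbon. For the measured compounds named here, neither measured step touches this part of the shared core, so no measured step bears directly on the change. In the absence of such a step, compound 3 is expected to give a higher number than compound 2, with a wide range, and the expected step is a 29-fold higher number from compound 2 to compound 3 (1.46 log units; beyond the scatter). Compound 3 is accordingly estimated at 2000 nM, between 300 nM and 15000 nM.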

Compound 3, half-maximal inhibitory concentration: 15000 nM
Estimate against measurement, compound 3: 7.5-fold (0.88 log units) below; measured number inside the range.
By their numbers in this assay, from the lowest: compounds 2 and 1 (each within the scatter of the next); then compound 3.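

In this assay, hydrogen in place of methoxy gives a 210-fold higher number from compound 2 to compound 3 (2.33 log units; beyond the scatter), the only step beyond the scatter among the compounds shown. It places the sensitivity of this series at the aromatic carbon ortho to a cyclopentyloxy group, and shows that the methoxy there cannot be dropped without a large rise in the number. Nothing shown gives a reason for this rise. From the compounds shown here alone, whether an ethoxy group, a hydroxyl or a fluorine at this place would keep the number near that of compound 2 stays open. So does whether the same change would cost as much with the 2-bromophenyl group of compound 1.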